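The source may hold more compounds than are shown below. What is called first, only, known or untested is meant among the compounds shown, and "the series" means these compounds.

- compound 1 `COc1ccc(-c2ccc(OC(F)(F)F)c(NC(=O)Nc3ccncc3)c2)cn1`: "not determined" (no result reported) in this series
- compound 2 `O=C(Nc1ccncc1)Nc1cc(-c2cncnc2)ccc1OC(F)(F)F`: 3990 nM in this series

For the measured compounds named here, in a functional assay on SMMC-7721 cells (Homo sapiens) for inhibition, read by MTT assay, with a stated time of 48 h (a lower number here means a stronger inhibitor, a higher number a weaker inhibitor), compound 2 gives 3990 nM as the only number available. Compound 1 has no result to set beside it, so compound 2 cannot yet be ranked against anything.

Compound 3 `O=C(Nc1nccs1)Nc1cc(-c2cncnc2)ccc1OC(F)(F)F` keeps the shared core of compound 2 and changes it in one place: 1,3-thiazol-2-yl in place of pyridin-4-yl on an amide-type nitrogen with 1,3-thiazol-2-yl in place of pyridin-4-yl on an amide-type nitrogen. Going by the values given here, no measured pair shows what this swap does, so neither size nor direction has direct support. With compound 2 at 3990 nM as the sole anchor, the expected outcome is a 1.1-fold higher number from compound 2 to compound 3 (0.05 log units; within the scatter) and no shift beyond the usual scatter. For compound 3 the estimated half-maximal inhibitory concentration is 4500 nM with an expected range of 1300 nM to 16000 nM in this assay once tested.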

Compound 3, half-maximal inhibitory concentration: 9350 nM
Beside the measured number, compound 3's estimate is 2.1-fold (0.32 log units) below it; low and high end bracket the measured number.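

In this assay, putting 1,3-thiazol-2-yl in place of pyridin-4-yl on the amide-type nitrogen gives a 2.3-fold higher number from compound 2 to compound 3 (0.37 log units; beyond the scatter) and so marks a modest loss of inhibition. For the compounds shown here, this is the first sign that the ring carried at this position affects the result, although the change is not large enough to remove activity altogether. Nothing measured here bears on the reason for this shift.

Compound 1 has no number, so the difference between it and compound 2 cannot be read. Going by these compounds, this single pair also cannot separate ring size from the identity of the hetero atoms, and it remains open how a plain phenyl ring, a pyridin-3-yl ring or a simple cyclohexyl group would behave on this nitrogen.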